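Ethyl in Place of Hydrogen: Expecting Little Change

The compounds below may be only part of what the source reports. "The series", "measured", "known", "first", "only" and "open" are said of these compounds alone.

Three measured compounds share one core and were tested in a functional assay on the whole organism for inhibition, with Rattus norvegicus as the target, at a dose of 10 mg/kg by the oral route; a higher number here means a stronger effect of the compound at the dose given, a lower number a weaker effect. Compound 1 `COc1cc(C(=O)Nc2nn[nH]n2)nc(-c2ccccc2)c1` gives 100%, compound 2 `O=C(Nc1nn[nH]n1)c1cccc(-c2ccccc2)n1` gives 81%, and compound 3 `Cc1cc(C(=O)Nc2nn[nH]n2)nc(-c2ccccc2)c1` gives 88%. Compound 3 stands second highest of the three: its number lies within the scatter of that of compound 2, while a number 12 percentage points lower from compound 1 to compound 3 (beyond the scatter). All measured steps concern a methoxy, methyl or hydrogen on an aromatic carbon: a number 19 percentage points lower from compound 1 to compound 2 (beyond the scatter), a number 12 percentage points lower from compound 1 to compound 3 (beyond the scatter), and a number 7 percentage points higher from compound 2 to compound 3 (within the scatter).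

Compound 4 `CCc1ccc(-c2cc(C)cc(C(=O)Nc3nn[nH]n3)n2)cc1` differs from compound 3 by ethyl in place of hydrogen on an aromatic carbon. Among the compounds with values here, no measured step touches the six-membered aromatic ring of carbon only, so none bears on this change directly. The nearest comparison is the small alkyl added in a number 7 percentage points higher from compound 2 to compound 3 (within the scatter), which stayed within the scatter. Therefore no step beyond the scatter is expected in this assay. Compound 4 is expected to give about 85%, with a range from 65% to 100%. This estimate means an expected a number 3 percentage points lower from compound 3 to compound 4 (within the scatter).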

Compound 4, a percentage reported as inhibition, in the whole organism at one dose (the size of the read-out at that dose, not a potency): 100%
Compound 4: the middle estimate sits 15 percentage points below what was measured; the range from low to high includes it.
By their numbers in this assay, from the lowest: compounds 2 and 3 (each within the scatter of the next); then compounds 1 and 4 (each within the scatter of the next).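

Within the data shown here, the six-membered aromatic ring of carbon only, untouched in the earlier compounds, proves able to shift the read-out: ethyl in place of hydrogen, para to a large group, gives a number 12 percentage points higher from compound 3 to compound 4 (beyond the scatter) in this assay. The step is modest, yet this single change lies beyond the scatter, whereas the small alkyl added to the shared core, a number 7 percentage points higher from compound 2 to compound 3 (within the scatter), stayed within it. Nothing available explains why this ethyl step occurs.

Only one group is shown at this place, so it remains open whether a shorter methyl, a longer propyl chain, an amine or a carboxylic acid there would give a similar number. Also open, on these data alone, is how ethyl at this place would act alongside the methoxy of compound 1 rather than the methyl of compound 3.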